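A few compounds are considered here, and "the series" means these few. Any claim that something is new, unique, unknown or untested is made for them only; others in the source may bear on it.

Compound 1 `C[C@]1(CN2CCc3nc(-c4ccccc4)ccc3C2)Cn2cc([N+](=O)[O-])nc2O1` and compound 3 `C[C@]1(CN2CCc3nc(-c4cccc(F)c4F)ccc3C2)Cn2cc([N+](=O)[O-])nc2O1` share one core with compound 2 `C[C@]1(CN2CCc3nc(-c4ccc(OC(F)(F)F)cc4)ccc3C2)Cn2cc([N+](=O)[O-])nc2O1` and differ from it only in the ring attached to that core. In an ADME assay on Vero cells (Chlorocebus sabaeus) for cytotoxicity, read by MTT assay, with a stated time of 72 h (a lower number here means that less compound is tolerated, a higher number that more compound is tolerated), compound 1 reaches the limit of the assay, > 32 ug/mL. Compound 3 also stops at the limit, > 32 ug/mL. For compound 2 the result is "not determined" (no result reported), so it stands without a number of its own. The step that the two limits leave unreadable from compound 1 to compound 3 has no readable size. Compound 4 `C[C@]1(CN2CCc3nc(-c4ccc(Cl)c(F)c4)ccc3C2)Cn2cc([N+](=O)[O-])nc2O1` differs from compound 2 in that (4-chloro-3-fluorophenyl in place of 4-(trifluoromethoxy)phenyl on an aromatic carbon). Going by the values given here, the only measured step gives no size, and two of three values rest at the limit of > 32 ug/mL in this assay, at which 2 of the 3 values shown sit; no shift beyond the scatter is expected. Compound 4 is estimated to give 40 ug/mL, within 25 ug/mL to 80 ug/mL, most likely again as a limit.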

Compound 4, half-maximal cytotoxic concentration: > 32 ug/mL
Compound 4: only a limit was reported (the forecaster's own chance of this, stated with the estimate: 75%); the middle value lies beyond the limit too.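

No step between compound 1, compound 3 and compound 4 can be read, since each result is only a limit: the limit of > 32 ug/mL in this assay, at which 3 of the 4 values shown sit.

From the compounds shown here alone, how far apart these compounds truly lie, and where compound 2 stands, remains open.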